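Replacing the Carbamoylphenyl Group with a Morpholine Amide

A few compounds are considered here, and "the series" means these few. Any claim that something is new, unique, unknown or untested is made for them only; others in the source may bear on it.

Three measured compounds share one core and differ only in the group attached to the five-membered ring. Compound 1 `COC(=O)c1ccc(-c2cnc(C(=O)CCCCCCc3ccccc3)o2)cc1` carries a methoxycarbonyl on its phenyl ring, and in an assay (Rattus norvegicus) for inhibition of Fatty-acid amide hydrolase 1 (Homo sapiens) (a higher number here means a weaker inhibitor, a lower number a stronger inhibitor), compound 1 gives 40 nM. Compound 2 `NS(=O)(=O)c1ccc(-c2cnc(C(=O)CCCCCCc3ccccc3)o2)cc1` carries a sulfamoyl in that place, and in this assay compound 2 gives 10 nM. Compound 3 `NC(=O)c1ccc(-c2cnc(C(=O)CCCCCCc3ccccc3)o2)cc1` carries a carbamoyl there, and in this assay compound 3 gives 10 nM. Both a 4.0-fold lower number from compound 1 to compound 2 (0.60 log units; beyond the scatter) and a 4.0-fold lower number from compound 1 to compound 3 (0.60 log units; beyond the scatter) are modest yet beyond the scatter, whereas no change at the digits printed from compound 2 to compound 3 (within the scatter). Compound 3 therefore stands level with compound 2 at the digits shown, the two sharing the lowest numbers, with compound 1 furthest away.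

Compound 4 `O=C(CCCCCCc1ccccc1)c1ncc(C(=O)N2CCOCC2)o1` has not been measured. Going by the values given here, its difference from compound 3 is as follows. (morpholin-4-yl)carbonyl in place of 4-carbamoylphenyl on an aromatic carbon None of the measured steps bears directly on this change: each of them swaps one substituent on the phenyl ring, while here the whole phenyl ring leaves and a saturated ring amide enters. The direction is thus open, and a change of this size is expected to move the number beyond the scatter. Compound 4 is estimated at 60 nM, within a range of 12 nM to 300 nM. That estimate means an expected 6.0-fold higher number from compound 3 to compound 4 (0.78 log units; beyond the scatter).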

Compound 4, inhibition constant: 24 nM
The estimate for compound 4 lay 2.5-fold (0.40 log units) above the measured number; measured number inside the range.
By their numbers in this assay, from the lowest: compounds 2 and 3 (each within the scatter of the next); then compounds 4 and 1 (each within the scatter of the next).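

The step of a 2.4-fold higher number from compound 3 to compound 4 (0.38 log units; beyond the scatter) is modest, even though the whole 4-carbamoylphenyl leaves this aromatic carbon next to the ring oxygen and (morpholin-4-yl)carbonyl enters. The earlier compounds shown here all kept the phenyl ring and varied only its substituent, so they could not show that inhibition in this assay survives with a six-membered non-aromatic ring in this place and with no hydrogen-bond donor on the group. This single swap changes the ring, the donor count and the acceptor count together, so it cannot say which of these accounts for the step, and nothing available here explains the step.

On these data alone, it remains open whether the morpholine ring itself matters or whether the carbonyl attached directly to the five-membered ring is enough, a question that a piperidine amide, a dimethylamide or a plain primary carboxamide in this place could answer. A carboxylic acid or a methyl ester on the same carbon would also show how far the morpholine amide can be reduced.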